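The source may hold more compounds than are shown below. What is called first, only, known or untested is meant among the compounds shown, and "the series" means these compounds.

For the measured compounds named here, in a functional assay on MCF7 cells (Homo sapiens) for antiproliferative activity, read by MTT assay, with a stated time of 48 h (on this read-out lower numbers stand for stronger inhibition and higher numbers for weaker inhibition), compound 1 (`COc1ccc2nc(NC(c3cn(-c4ccccc4)nc3-c3ccc([N+](=O)[O-])cc3)c3c(O)ccc4ccccc34)sc2c1`) gives 13300 nM and compound 2 (`COc1ccc(-c2nn(-c3ccccc3)cc2C(Nc2nc3ccc(OC)cc3s2)c2c(O)ccc3ccccc23)cc1`) gives 41800 nM as the higher of the two numbers so far. Compound 3 (`COc1ccc2nc(NC(c3cn(-c4ccccc4)nc3-c3cccc([N+](=O)[O-])c3)c3c(O)ccc4ccccc34)sc2c1`) differs from compound 2 as follows: 3-nitrophenyl in place of 4-methoxyphenyl on an aromatic carbon. Going by the values given here, only one measured step bears on this change, a modest one beyond the scatter, with methoxy in place of nitro on an aromatic carbon. Among the compounds with values here, compound 3 restores a nitro in place of the methoxy, but as 3-nitrophenyl, which no measured compound carries. Because of a 3.1-fold higher number from compound 1 to compound 2 (0.50 log units; beyond the scatter) a move to a lower number in this assay is expected, of similar or somewhat smaller size. The estimated step is a 2.3-fold lower number from compound 2 to compound 3 (0.37 log units; beyond the scatter) as a working figure. For compound 3 the estimate is 18000 nM as the expected value (7000 nM to 42000 nM).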

Compound 3, half-maximal inhibitory concentration: 26800 nM
The estimate for compound 3 lay 1.5-fold (0.17 log units) below the measured number; the measured number falls inside the stated range.
By their numbers in this assay, from the lowest: compounds 1, 3 and 2 (each within the scatter of the next, the first and the last beyond it).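

In this assay the exchange of 4-methoxyphenyl for 3-nitrophenyl on this carbon of the five-membered ring gives a 1.6-fold lower number from compound 2 to compound 3 (0.19 log units; within the scatter) and so stays within the scatter. The exchange of 4-nitrophenyl for 3-nitrophenyl gives a 2.0-fold higher number from compound 1 to compound 3 (0.30 log units; within the scatter) and also stays within it, so compound 3 cannot be told apart from either neighbour, although a 3.1-fold higher number from compound 1 to compound 2 (0.50 log units; beyond the scatter) separates those two. Nothing on hand explains these numbers.

Whether the placing of the nitro group on this phenyl ring matters therefore remains unresolved. Also open, as far as these compounds go, is what an amine or a carboxylic acid on this phenyl ring would give, and whether any group at this carbon can move the number well beyond the narrow span of these three compounds.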